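The source may hold more compounds than are shown below. What is called first, only, known or untested is meant among the compounds shown, and "the series" means these compounds.

Measured compounds:
compound 1 `CCCCCCCCc1ccc(OCC(=O)Cn2nnc(-c3cccc(S(=O)(=O)N(C)C)c3)n2)cc1`: 9%
compound 2 `CCCCCCCCc1ccc(OCC(=O)Cn2nnnc2-c2ccc(Cl)cc2)cc1`: 45%

In an ADME assay on S9 fraction from liver (Rattus norvegicus) for metabolic stability, read by LC-MS, using NADPH, with a stated time of 30 min (a lower number here means that less of the compound is left, a higher number that more of the compound is left), compound 2 gives 45%, the higher of the two numbers obtained so far. Compound 1 gives 9%, which lies lower by more than the usual scatter. For the measured compounds named here, no two measured compounds differ in a single place, so no single-point step is known; the two values only show that the series spans a wide range in this assay.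

Compound 3 `CCCCCCCCc1ccc(OCC(=O)Cn2nnnc2C(=O)OCC)cc1` has not yet been measured in this assay. Its change from compound 2: ethoxycarbonyl in place of 4-chlorophenyl on an aromatic carbon. Going by the values given here, nothing measured so far covers this change. The step of a number 20 percentage points lower from compound 2 to compound 3 (beyond the scatter) is estimated as a fall beyond the scatter, with little footing for its size. Compound 3 is expected to give 25% in this assay, with a range from 5% to 50%.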

Compound 3, percent of the compound remaining: 33%
Compound 3: the middle estimate sits 8 percentage points below what was measured, and the stated range covers the measured number.
By their numbers in this assay, from the lowest: compound 1; then compound 3; then compound 2.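

In this assay, ethoxycarbonyl in place of 4-chlorophenyl on this aromatic carbon gives a number 12 percentage points lower from compound 2 to compound 3 (beyond the scatter). The position therefore tolerates a group with no ring, and compound 3 still stands at 33%, so a six-membered aromatic ring of carbon only is not required here for part of the compound to remain. Nothing at hand indicates which part of either compound is consumed or what lies behind the step.

As far as these compounds go, whether the fall follows from losing the ring or from bringing in the ethoxycarbonyl stays open; a carboxylic acid, an amide or an unsubstituted phenyl on this carbon would help to separate the two. This pair also says nothing about the contribution of the shared core and its long chain.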